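Swapping one five-membered ring for another on an inactive core

The source may report more compounds than this note shows. Statements on the series, on what has been measured and on what is new or still open speak of the compounds shown alone.

Of the compounds shown here, three sharing one core have been measured in a functional assay on CHO cells for agonist activity at Alpha-1B adrenergic receptor (Homo sapiens), read by FLIPR and calcium flux; on this read-out higher numbers stand for an effect only at larger amounts of compound and lower numbers for an effect already at smaller amounts. Compound 1 `CCCS(=O)(=O)Nc1cccc2c1CCC2c1ncc[nH]1` carries a (propylsulfonyl)amino group on the aromatic ring; in this assay compound 1 gives only a limit, > 10000 nM. Compound 2 `CS(=O)(=O)Nc1cccc2c1CCC2c1ncc[nH]1` shortens that group to methanesulfonamido, and in this assay compound 2 also gives only a limit, > 10000 nM. Compound 3 `Cc1oncc1-c1cccc2c1CCC2c1ncc[nH]1` carries a 5-methyl-1,2-oxazol-4-yl group in the same place, and in this assay compound 3 gives only a limit as well, > 10000 nM. Compound 3 therefore stands where every measured compound stands, at the limit of > 10000 nM in this assay, at which 3 of the 3 values shown sit. The steps a step that the two limits leave unreadable from compound 1 to compound 3 and a step that the two limits leave unreadable from compound 2 to compound 3 consequently have no readable size, and neither does a step that the two limits leave unreadable from compound 1 to compound 2.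

Compound 4 `Cn1cc(-c2cccc3c2CCC3c2ncc[nH]2)cn1` differs from compound 3 by one exchange: 1-methyl-1H-pyrazol-4-yl in place of 5-methyl-1,2-oxazol-4-yl on an aromatic carbon. Among the compounds with values here, of the measured steps, a step that the two limits leave unreadable from compound 1 to compound 3 and a step that the two limits leave unreadable from compound 2 to compound 3 alter the same aromatic carbon as this exchange, so they are the ones that bear on it; both are unreadable, and no measured step gives a direction or size. The expected step that the limit leaves unreadable from compound 3 to compound 4 is none beyond the scatter, with a further limit the most likely outcome for compound 4. Compound 4 is estimated at 12000 nM, within a range from 4000 nM to 40000 nM.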

Compound 4, half-maximal effective concentration: > 10000 nM
Compound 4: only a limit was reported (the forecaster's own chance of this, stated with the estimate: 85%); the middle value does not contradict the limit.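

Compound 4, like compound 1, compound 2 and compound 3, gives only a limit in this assay, so none of the steps to compound 4 can be read: the limit of > 10000 nM in this assay, at which 4 of the 4 values shown sit.

The compounds shown leave open whether any group on this aromatic carbon of the shared core can give a readable value in this assay, and how far these groups differ.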